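Swapping Trifluoromethyl for Hydroxyoxetane: a Stability Outlook

The source may hold more compounds than are shown below. What is called first, only, known or untested is meant among the compounds shown, and "the series" means these compounds.

Three compounds that share one amide core have been run in an ADME assay on microsomes from liver (Rattus norvegicus, strain Sprague-Dawley) for metabolic stability, read by HPLC, using NADPH, with stated times of 5 min and 60 min, tested at 10 uM; a lower number here means that the compound disappears faster, a higher number that the compound lasts longer. Compound 1 `CC(C)(C)c1ccc(C(=O)NCc2ccc(NS(=O)(=O)C3CC3)cc2Cl)cc1` gives 0.55 h, and compound 2 `CC(C)(C)c1ccc(C(=O)NCc2ccc(NS(C)(=O)=O)cc2F)cc1` gives 0.483 h. Compound 3 `CS(=O)(=O)Nc1ccc(CNC(=O)c2ccc(C(F)(F)F)cc2)c(Cl)c1` gives 2.43 h, the highest of the three numbers, and its gap to each of the other two lies beyond the usual scatter, with compound 1 the nearer of the pair. Compound 4 `CS(=O)(=O)Nc1ccc(CNC(=O)c2ccc(C3(O)COC3)cc2)c(Cl)c1` has not yet been measured in this assay. It differs from compound 3 in one place: 3-hydroxyoxetan-3-yl in place of trifluoromethyl on an aromatic carbon. For the measured compounds named here, both other compounds differ from compound 3 in several places at once, so no single measured step shows what this change alone does. The expected step is a 1.6-fold lower number from compound 3 to compound 4 (0.21 log units; within the scatter), a modest lowering. Compound 4 is expected to give 1.5 h, within a range from 0.5 h to 4 h.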

Compound 4, half-life: 4.23 h
The estimate for compound 4 lay 2.8-fold (0.45 log units) below the measured number; the whole stated range lies below it.
By their numbers in this assay, from the lowest: compounds 2 and 1 (each within the scatter of the next); then compounds 3 and 4 (each within the scatter of the next).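

Placing 3-hydroxyoxetan-3-yl in place of trifluoromethyl on this aromatic carbon gives a 1.7-fold higher number from compound 3 to compound 4 (0.24 log units; within the scatter) in this assay, so the two compounds cannot be told apart here. This single-place step shows that the half-life at this position is held when a group with a four-membered ring and a hydrogen-bond donor enters. No measured evidence accounts for this result. Still open, from the compounds shown here alone, is how other groups at this position, such as an amine, a carboxylic acid or a longer chain, would read.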